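The compounds below may be only part of what the source reports. "The series", "measured", "known", "first", "only" and "open" are said of these compounds alone.

Measured so far:
compound 1 `CC1(C)O[C@H]2O[C@H](Cn3cc(CN4C(=O)/C(=N\Nc5ccc(C#N)cc5)c5ccccc54)nn3)[C@H](O)[C@H]2O1`: in an ADME assay on Vero cells (Chlorocebus sabaeus) for cytotoxicity, read by fluorescence and resazurin assay, with a stated time of 3 days (on this read-out higher numbers stand for lower toxicity in this test and lower numbers for higher toxicity in this test), compound 1 gives 105000 nM
compound 2 `COc1ccc(N/N=C2\C(=O)N(Cc3cn(O[C@@H]4O[C@H](CO)[C@H](O)[C@H](O)[C@H]4O)nn3)c3ccccc32)cc1`: in this assay compound 2 gives 76200 nM

Only these two numbers exist in the series, and they sit within the scatter of each other; compound 2 is not separated from compound 1 by anything a repeat measurement could not undo. Within the data shown here, no step between measured compounds that differ in one place is available, so no measured step can be quoted.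

Compound 3 `N#Cc1ccc(N/N=C2\C(=O)N(Cc3cn(O[C@@H]4O[C@H](CO)[C@H](O)[C@H](O)[C@H]4O)nn3)c3ccccc32)cc1` is to be measured in this assay. Against compound 2 it carries cyano in place of methoxy on an aromatic carbon. The cyano on the ring bearing the amino group is the same group that compound 1 carries, and compound 1 gives 105000 nM, within the scatter of compound 2. On this basis no step beyond the scatter is expected in either direction for compound 3, and the estimated step is a 1.2-fold higher number from compound 2 to compound 3 (0.07 log units; within the scatter). For compound 3 the expected value is 90000 nM, with a range from 45000 nM to 180000 nM.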

Compound 3, half-maximal cytotoxic concentration: 93700 nM
Compound 3: middle estimate off by 1.0-fold (0.02 log units), on the low side; measured number inside the range.
By their numbers in this assay, from the lowest: compounds 2, 3 and 1 (each within the scatter of the next).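

In this assay, the place para to a large group now has a measured step: cyano in place of methoxy gives a 1.2-fold higher number from compound 2 to compound 3 (0.09 log units; within the scatter), so this exchange does not separate the pair. With the cyano held constant, the group on the aromatic nitrogen now has a measured step too: exchanging it gives a 1.1-fold lower number from compound 1 to compound 3 (0.05 log units; within the scatter), also within the scatter. No measurement at hand bears on the reason for either result.

From the compounds shown here alone, whether an amine or a carboxylic acid at this place on the aromatic ring would give a step beyond the scatter remains open. Also open, going by these compounds, is whether a longer chain on the aromatic nitrogen would separate from compound 3 in this read-out.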